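From ethyl to methyl: the step to compound 4

A few compounds are considered here, and "the series" means these few. Any claim that something is new, unique, unknown or untested is made for them only; others in the source may bear on it.

Measured so far in a functional assay on A549 cells (Homo sapiens) for cytotoxicity, read by XTT assay, with a stated time of 72 h; a lower number here means a stronger inhibitor, a higher number a weaker inhibitor:
- Compound 1 `COc1ccc(C(=O)c2cc(OC)c(OC)c(OC)c2)cc1[N+](=O)[O-]`: > 10000 nM
- Compound 2 `CCn1ccc2cc(Cc3ccc(OC)c(OC)c3OC)ccc21`: > 10000 nM
- Compound 3 `COc1ccc(C(O)c2ccc3ccccc3c2)c(OC)c1OC`: > 10000 nM

Compound 2 has only a limit of the assay, not a number: > 10000 nM. The other two compounds end the same way, as shown by the limit of > 10000 nM in this assay, at which 3 of the 3 values shown sit. Compound 4 `COc1ccc(Cc2ccc3c(ccn3C)c2)c(OC)c1OC` has not yet been measured. It differs from compound 2 by one small change, hydrogen in place of methyl on a saturated chain carbon bound to an aromatic nitrogen, which turns ethyl into methyl. Going by the values given here, no measured pair shows what this change does, so the expected step of a number no higher from compound 2 to compound 4 (the limit leaves the size open) is none beyond the usual scatter, with no direction favoured. For compound 4 the estimate is 10000 nM, with an expected range from 2000 nM to 30000 nM.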

Compound 4, half-maximal inhibitory concentration: 600 nM
Compound 4: middle estimate off by 17-fold (1.22 log units), on the high side; measured number below the stated range.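

In this assay, the change from ethyl to methyl gives an at least 16-fold lower number from compound 2 to compound 4 (1.22 log units; beyond the scatter), so this small change can separate a measurable number from none. Compound 2 gives > 10000 nM, a limit of the assay, which leaves the full size of the step open. Compound 4 is the only compound here with a number, while the others stop at that limit: the limit of > 10000 nM in this assay, at which 3 of the 4 values shown sit.

Still open, on these data alone, is how other groups at this place would compare with methyl, such as a propyl or a 2-hydroxyethyl chain.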